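Aryl ether swap: expected cytotoxicity of compound 3

This account rests on a few compounds, and the source may have more. Where it says the series, first, only, none or still open, it means among the compounds named here.

compound 1 `Cc1cn(C2CCN(Cc3cccc(Oc4ccc(Cl)cc4)c3)CC2)c(=O)[nH]c1=O` gives 25100 nM in an ADME assay on MRC5 cells (Homo sapiens) for cytotoxicity, read by fluorescence and resazurin assay, with a stated time of 3 days; a higher number here means a weaker inhibitor, a lower number a stronger inhibitor
compound 2 `Cc1cn(C2CCN(Cc3cncc(Oc4cc(Cl)cc(Cl)c4)c3)CC2)c(=O)[nH]c1=O` gives > 64000 nM in this assay, a limit of the assay and not a number

Among the numbers shown, compound 1 holds the only plain value. Compound 2 sits at the limit of > 64000 nM in this assay, at which 1 of the 2 values shown sits, which is only a limit. Compound 3 `Cc1cn(C2CCN(Cc3cccc(Oc4cc(F)cc(F)c4)c3)CC2)c(=O)[nH]c1=O` is not yet measured; it differs from compound 1 by 3,5-difluorophenyl in place of 4-chlorophenyl on an oxygen on an aromatic ring. Among the compounds with values here, no step between measured compounds is available, so in this assay a shift from compound 1 of no more than the usual scatter is expected. Compound 3 is thus estimated at 30000 nM, with a range from 12000 nM to 64000 nM. That estimate means an expected step of a 1.2-fold higher number from compound 1 to compound 3 (0.08 log units; within the scatter).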

Compound 3, half-maximal inhibitory concentration: > 64000 nM
Compound 3 gave a limit, no number; the forecaster's own chance of this, stated with the estimate: 35%; middle value at least 2.1-fold (0.32 log units) away from the limit.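

Within this assay the swap of 4-chlorophenyl for 3,5-difluorophenyl on an oxygen on an aromatic ring gives an at least 2.5-fold higher number from compound 1 to compound 3 (0.40 log units; beyond the scatter) with the rest of the molecule unchanged. Within the data shown here, this is the first step that can be read at this position, and it shows that changing this ring alone can weaken the effect on the cells. Compound 3 gives only a limit of the assay and not a number: the limit of > 64000 nM in this assay, at which 2 of the 3 values shown sit.

Going by these compounds, how far the true value of compound 3 lies past that limit stays open. Also open, on these data alone, is whether losing the chlorine or adding the fluorines accounts for the step, and how a ring carrying an amine or a carboxylic acid would read.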